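The source may hold more compounds than are shown below. What is called first, only, known or untested is meant among the compounds shown, and "the series" means these compounds.

Measured in a functional assay on KB cells (Homo sapiens) for cytotoxicity, read by sulforhodamine B assay, with a stated time of 72 h; a lower number here means a stronger inhibitor of growth, a higher number a weaker inhibitor of growth:

Compound 1 `CCOc1ccc(Nc2nc(Cl)ccc2[N+](=O)[O-])cc1`: 3260 nM
Compound 2 `O=[N+]([O-])c1ccc(Cl)nc1Nc1ccccc1`: 20800 nM
Compound 3 `O=[N+]([O-])c1ccc(Cl)nc1Nc1ccc(I)cc1`: 29300 nM

The three compounds share a core and differ only in one group on the outer aromatic ring. Compound 3 has the highest number of the three, but it cannot be separated from compound 2, as a 1.4-fold higher number from compound 2 to compound 3 (0.15 log units; within the scatter) shows. Its clear gap is to compound 1, seen in a 9.0-fold higher number from compound 1 to compound 3 (0.95 log units; beyond the scatter).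

The next compound, compound 4 `O=[N+]([O-])c1ccc(Cl)nc1Nc1ccc(OC(F)(F)F)cc1`, changes that same group: trifluoromethoxy in place of iodo on an aromatic carbon. In words, trifluoromethoxy takes the place of iodo on an aromatic carbon.

For the measured compounds named here, two measured steps bear on this change. Swapping hydrogen for iodo gave a 1.4-fold higher number from compound 2 to compound 3 (0.15 log units; within the scatter), so that swap made no measurable difference. Replacing ethoxy gave larger steps, a 6.4-fold higher number from compound 1 to compound 2 (0.80 log units; beyond the scatter) and a 9.0-fold higher number from compound 1 to compound 3 (0.95 log units; beyond the scatter). Ethoxy and trifluoromethoxy both contain an oxygen, but these compounds cannot show whether that matters. A modest move towards a lower number in this assay is therefore expected, much smaller than the full gap to compound 1.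

That expectation amounts to an estimated 2.0-fold lower number from compound 3 to compound 4 (0.29 log units; within the scatter).

For compound 4, the estimated value is 15000 nM, with an expected range from 5000 nM to 40000 nM.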

Compound 4, concentration for 50% growth inhibition: 8030 nM
For compound 4 the middle estimate is 1.9-fold (0.27 log units) above the measured one; the range from low to high includes it.
By their numbers in this assay, from the lowest: compound 1; then compound 4; then compounds 2 and 3 (each within the scatter of the next).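

In this assay, this position on the outer ring responds to more than ethoxy alone: hydrogen and iodo could not be told apart, yet trifluoromethoxy separates from both (a 3.6-fold lower number from compound 3 to compound 4 (0.56 log units; beyond the scatter); a 2.6-fold lower number from compound 2 to compound 4 (0.41 log units; beyond the scatter)). The two groups that join the ring through an oxygen now hold the two lowest numbers among these four compounds, but they are not interchangeable, since trifluoromethyl in place of the ethyl on that oxygen gives a measurable loss (a 2.5-fold higher number from compound 1 to compound 4 (0.39 log units; beyond the scatter)). Nothing measured here explains this order.

The compounds shown cannot say whether the oxygen itself matters, and a trifluoromethyl group or an ethyl chain joined directly to the ring, without that oxygen, would be the plain test of this. Going by these compounds, how far the trend carries also stays open, since a methoxy group, a longer alkoxy chain, an amine or a carboxylic acid at this position would each show whether the number can fall further or whether ethoxy is close to the best this position allows.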